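Moving bromine on the sulfonyl aryl group

A few compounds are considered here, and "the series" means these few. Any claim that something is new, unique, unknown or untested is made for them only; others in the source may bear on it.

In a functional assay on HL-60 cells (Homo sapiens) for cytotoxicity, read by MTT assay (on this read-out higher numbers stand for weaker inhibition and lower numbers for stronger inhibition), compound 1 `COc1ccc(S(=O)(=O)NC(C)C2=CC(=O)c3c(O)ccc(O)c3C2=O)cc1` gives 20 nM, compound 2 `CC(NS(=O)(=O)c1ccc(F)cc1)C1=CC(=O)c2c(O)ccc(O)c2C1=O` gives 90 nM, and compound 3 `CC(NS(=O)(=O)c1ccc(Br)cc1)C1=CC(=O)c2c(O)ccc(O)c2C1=O` gives 100 nM. Compound 3 therefore stands level with compound 2, and both sit on the weaker side of compound 1.

Compound 4 `CC(NS(=O)(=O)c1ccccc1Br)C1=CC(=O)c2c(O)ccc(O)c2C1=O` has 2-bromophenyl in place of 4-bromophenyl on a sulfonyl sulfur.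

Two measured steps replace methoxy with a halogen, and both are modest: a 4.5-fold higher number from compound 1 to compound 2 (0.65 log units; beyond the scatter) and a 5.0-fold higher number from compound 1 to compound 3 (0.70 log units; beyond the scatter). The step that exchanges one halogen for another, a 1.1-fold higher number from compound 2 to compound 3 (0.05 log units; within the scatter), stays within the scatter. None of the three moves a group to another ring position, so the series offers only indirect guidance, and the range is kept wide.

No change beyond the scatter is expected, and the direction is left open. The estimated step is a 1.1-fold higher number from compound 3 to compound 4 (0.04 log units; within the scatter). For compound 4 the estimated value is 110 nM, within an expected range of 35 nM to 350 nM.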

Compound 4, half-maximal inhibitory concentration: 120 nM
For compound 4 the middle estimate is 1.1-fold (0.04 log units) below the measured one, and the stated range covers the measured number.
By their numbers in this assay, from the lowest: compound 1; then compounds 2, 3 and 4 (each within the scatter of the next).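

In this assay, for the compounds shown here, the change from 4-bromophenyl to 2-bromophenyl on the sulfonyl sulfur is the first move of a group to another ring position, and it stays within the scatter (a 1.2-fold higher number from compound 3 to compound 4 (0.08 log units; within the scatter)). The 2-bromophenyl group also stands level with 4-fluorophenyl (a 1.3-fold higher number from compound 2 to compound 4 (0.12 log units; within the scatter)), while the gap to 4-methoxyphenyl remains beyond the scatter (a 6.0-fold higher number from compound 1 to compound 4 (0.78 log units; beyond the scatter)), so within these four compounds only compound 1 stands apart. No supporting data bear on why the bromine position makes no visible difference here.

From the compounds shown here alone, whether an amine or a carboxylic acid in place of bromine on the aryl group would keep the number near that of compound 4 remains open. Also open, going by these compounds, is whether the gap held by compound 1 survives moving its methoxy group to another ring position.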